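Propargylamine series: benzyl to methyl on the amine nitrogen

A few compounds are considered here, and "the series" means these few. Any claim that something is new, unique, unknown or untested is made for them only; others in the source may bear on it.

Measured so far in an assay on isolated protein for inhibition of Amine oxidase [flavin-containing] A (Rattus norvegicus); a higher number here means a weaker inhibitor, a lower number a stronger inhibitor:
compound 1, `CC(C)NCc1cn(Cc2ccccc2)c2ccccc12`: 133000 nM
compound 2, `C#CCN(Cc1ccccc1)Cc1cc2ccccc2n1C`: 10000 nM

Compound 2 holds the lower of the two numbers; compound 1, which shares no single-point relation to it, sits well above it, and the gap between them lies beyond the usual scatter. Compound 2 is therefore the reference point for the next step.

Compound 3, `C#CCN(C)Cc1cc2ccccc2n1C`, is not yet measured. Relative to compound 2 the change is hydrogen in place of phenyl on a saturated chain carbon bound to an amine nitrogen; read one bond further out it is benzyl to methyl. The propargyl group on the amine nitrogen and the remainder of the shared core are unchanged.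

For the measured compounds named here, no measured pair in this set reports a step of this kind, so the expectation rests only on compound 2. With the propargyl amine retained, the step from compound 2 to compound 3 is expected to be small in this assay, close to or within the scatter, a 1.5-fold higher number from compound 2 to compound 3 (0.18 log units; within the scatter), with a slight lean towards a weaker number. Compound 3 is estimated at 15000 nM, within a range of 4000 nM to 60000 nM.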

Compound 3, inhibition constant: 0.3 nM
The estimate for compound 3 lay 50000-fold (4.70 log units) above the measured number, outside the stated range (below it).
By their numbers in this assay, from the lowest: compound 3; then compound 2; then compound 1.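

In this assay the substituent on the amine nitrogen proves far from neutral: with the propargyl group and the shared core unchanged, benzyl to methyl gives a 33000-fold lower number from compound 2 to compound 3 (4.52 log units; beyond the scatter) and is a large step. For the compounds shown here, the earlier compounds offered no single-point pair, so this is the first single change read, and compound 3 at 0.3 nM replaces compound 2 as the reference point for further steps. No measurement shown gives a reason for a step of this size.

One step on one scaffold leaves open how the number moves with other groups in this place, such as ethyl, a longer chain or a plain hydrogen on the amine nitrogen, and so whether the change tracks the loss of the phenyl ring or something specific to methyl. Also open, as far as these compounds go, is whether the same step holds when the propargyl group itself gives way to an allyl or a cyclopropyl group, since both compounds of this pair carry it.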